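Working notes: tert-butyl in place of pentyl

This account rests on a few compounds, and the source may have more. Where it says the series, first, only, none or still open, it means among the compounds named here.

- compound 1 `CCCCCC=Cc1cc(-c2ccc3cc(C(=O)O)ccc3c2)ccc1O`: 2.44 ug/mL
- compound 2 `CCCCCc1cc(-c2ccc3cc(CO)ccc3c2)ccc1O`: 3.27 ug/mL

In a functional assay on HepG2 cells (Homo sapiens) for cytotoxicity, read by WST assay, with a stated time of 24 h (on this read-out higher numbers stand for lower toxicity in this test and lower numbers for higher toxicity in this test), compound 2 gives 3.27 ug/mL, within the scatter of compound 1 at 2.44 ug/mL. Compound 3 `CC(C)(C)c1cc(-c2ccc3cc(CO)ccc3c2)ccc1O` carries tert-butyl in place of pentyl on an aromatic carbon, ortho to a hydroxy group: tert-butyl in place of pentyl on an aromatic carbon. Among the measured compounds shown here, no measured step sizes this change, so no step beyond the scatter is expected, in either direction. The expected step is a 1.1-fold higher number from compound 2 to compound 3 (0.03 log units; within the scatter). For compound 3 the estimate in this assay is 3.5 ug/mL, with an expected range of 1.7 ug/mL to 8 ug/mL.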

Compound 3, concentration lethal to 50% of the cells: 7.5 ug/mL
Compound 3: middle estimate off by 2.1-fold (0.33 log units), on the low side, and the stated range covers the measured number.
By their numbers in this assay, from the lowest: compounds 1 and 2 (each within the scatter of the next); then compound 3.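

Among the compounds shown here, at this aromatic carbon, ortho to a hydroxy group, the alkyl group does change the number in this assay: tert-butyl in place of pentyl gives a 2.3-fold higher number from compound 2 to compound 3 (0.36 log units; beyond the scatter), the first step that can be read. The higher number stands for lower toxicity in this test, so this position is not indifferent to the alkyl group it carries. A straight butyl chain would be needed to tell whether the step follows the branching or the shorter chain, and an amine at this carbon remains untested in the compounds shown. Nothing at hand accounts for the step.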